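The source may hold more compounds than are shown below. What is called first, only, known or untested is meant among the compounds shown, and "the series" means these compounds.

Of the compounds shown here, two have been measured so far in an assay on HEK293 cells for inhibition of Steryl-sulfatase (Homo sapiens), tested at 1 uM; a lower number here means a weaker effect, a higher number a stronger effect of the compound at the concentration tested. Going by the values given here, compound 2 `CCCN(Cc1ccccc1)c1ccc(C(=O)N2CCc3ccc(OS(N)(=O)=O)cc3C2)cc1` gives 94.3% in this assay, the highest of the two numbers, although the only other number lies within the scatter of it. That other compound is compound 1 `CCN(Cc1cccnc1)c1ccc(C(=O)N2CCc3ccc(OS(N)(=O)=O)cc3C2)cc1`, which in this assay gives 85.2%. Among the compounds with values here, the one measured step, a number 9.1 percentage points higher from compound 1 to compound 2 (within the scatter), is within the scatter, so it shows no real change.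

Compound 3 `CCN(Cc1cccc(Br)c1)c1ccc(C(=O)N2CCc3ccc(OS(N)(=O)=O)cc3C2)cc1` has not yet been measured in this assay. It differs from compound 2 in one place: (3-bromobenzyl)(ethyl)amino in place of benzyl(propyl)amino on an aromatic carbon.

Within the data shown here, the single measured step bears on this change, since it also swaps one amino group for another at the same aromatic carbon, para to a large group, and that step, a number 9.1 percentage points higher from compound 1 to compound 2 (within the scatter), stayed within the scatter. With only this to go on, no step beyond the scatter is expected for compound 3, so its estimated step is a number 5.3 percentage points lower from compound 2 to compound 3 (within the scatter). Compound 3 is therefore expected to give about 89% in this assay, within a range from 74% to 98%.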

Compound 3, a percentage reported as inhibition, at one concentration (the size of the read-out at that concentration, not a potency): 97.2%
Estimate against measurement, compound 3: 8.2 percentage points below, and the stated range covers the measured number.
By their numbers in this assay, from the lowest: compounds 1, 2 and 3 (each within the scatter of the next, the first and the last beyond it).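

The step of a number 2.9 percentage points higher from compound 2 to compound 3 (within the scatter) shows that in this assay this amino group, on an aromatic carbon para to a large group, can change in two ways at once with no real effect on the read-out: the propyl chain gives way to an ethyl, and the benzyl ring gains a bromine. Going by these compounds alone, the step of a number 12 percentage points higher from compound 1 to compound 3 (beyond the scatter) is the first in this set to pass the scatter, and it is modest; with the ethyl group held constant, it links a 3-bromophenyl in place of pyridin-3-yl on the saturated chain carbon to a higher number at the single concentration tested. Nothing shown here gives a reason for either step.

The combined change from compound 2 to compound 3 leaves the separate contributions of the bromine and the chain length unresolved, and a benzyl(ethyl)amino group would pull them apart. Compound 2 and compound 3 also lie close to complete inhibition, so a lower test concentration or measurements across a range of concentrations would be needed to tell whether their effects truly match, and a chlorine or a methoxy group in place of the bromine remains an open question.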